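Swapping a Chloro for a Phenyl on the Pyridine

This account rests on a few compounds, and the source may have more. Where it says the series, first, only, none or still open, it means among the compounds named here.

The measured compounds and their values in an in vitro functional assay on SH-EP1 cells for agonist activity at Neuronal acetylcholine receptor; alpha4/beta2 (Homo sapiens), read by FLIPR and calcium flux; on this read-out lower numbers stand for smaller maximal responses and higher numbers for larger maximal responses:

Compound 1, `Fc1ccc(C2=CC3CNCC(C2)C3)cn1`: 136%
Compound 2, `C1=C(c2cncnc2)CC2CNCC1C2`: 145%
Compound 3, `Clc1ccc(C2=CC3CNCC(C2)C3)cn1`: 152%

Compound 3 gives the largest number of the three, but compound 2 lies within the scatter of it, so the two cannot be ranked; only compound 1 sits clearly lower, as the step of a number 16 percentage points higher from compound 1 to compound 3 (beyond the scatter) shows.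

Compound 4, `C1=C(c2ccc(-c3ccccc3)nc2)CC2CNCC1C2`, is not yet measured. It differs from compound 3 by phenyl in place of chloro on an aromatic carbon.

For the measured compounds named here, only one measured step touches the same place: a number 16 percentage points higher from compound 1 to compound 3 (beyond the scatter), a swap of one halogen for another. The change to compound 4 is of a different kind, since a whole six-membered ring of carbon enters where a single chlorine left, and nothing measured here shows what such a group does at this position. Going by the values given here, the single known step gives no firm guide, so the expectation is uncertain and wide. The estimate for compound 4 is a somewhat smaller maximal response than compound 3, a number 27 percentage points lower from compound 3 to compound 4 (beyond the scatter), which would give a value of 125% with a range from 75% to 165%.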

Compound 4, largest response reached (reported as percent of maximum), in percent of the reference or control that the assay uses: 18%
Compound 4: middle estimate off by 107 percentage points, on the high side, and the stated range ends above it.
By their numbers in this assay, from the lowest: compound 4; then compounds 1, 2 and 3 (each within the scatter of the next, the first and the last beyond it).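

Replacing a halogen with phenyl at this aromatic carbon, next to the ring nitrogen, has a far larger effect than the halogen swap alone suggested: phenyl in place of chloro gives a number 134 percentage points lower from compound 3 to compound 4 (beyond the scatter) and phenyl in place of fluoro gives a number 118 percentage points lower from compound 1 to compound 4 (beyond the scatter) in this assay while the halogen swap gave only a number 16 percentage points higher from compound 1 to compound 3 (beyond the scatter) on the same read-out. The shared core therefore does not secure a large maximal response by itself, and the group at this one position can take most of that response away. Nothing available here explains why phenyl has this effect.

The compounds shown jump from a single halogen atom straight to a whole ring of six carbons, so it remains open whether the response falls gradually across that gap or only with phenyl itself. A methyl, a methoxy or an amine at the same carbon would help to fill that gap, and a phenyl bearing its own substituents would show whether any response can be recovered with the ring in place.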